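Sulfonyl in place of carbamoyl on the amine nitrogen

This account rests on a few compounds, and the source may have more. Where it says the series, first, only, none or still open, it means among the compounds named here.

Measured compounds:
Compound 1, `CCCCNC(=S)NC1=C(C#N)C(c2ccc(Cl)cc2Cl)C2=C(CCCC2=O)N1c1ccc(S(N)(=O)=O)cc1`: 35%
Compound 2, `N#CC1=C(NC(N)=O)N(c2ccc(S(N)(=O)=O)cc2)C2=C(C(=O)CCC2)C1c1ccc(Cl)cc1Cl`: 40%

Both readings come from a functional assay on Ehrlich cells (Mus musculus) for cytotoxicity, read by trypan blue exclusion, with a stated time of 2 h, tested at 50 ug/mL; on this read-out higher numbers stand for a stronger effect at the one concentration tested and lower numbers for a weaker effect. Compound 2 sits at the top of the two numbers shown, yet a number 5 percentage points higher from compound 1 to compound 2 (within the scatter) is within the scatter, so compound 1 and compound 2 cannot be told apart on this evidence.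

Compound 3, `N#CC1=C(NS(=O)(=O)c2ccc([N+](=O)[O-])cc2)N(c2ccc(S(N)(=O)=O)cc2)C2=C(C(=O)CCC2)C1c1ccc(Cl)cc1Cl`, carries (4-nitrophenyl)sulfonyl in place of carbamoyl on an amine nitrogen. Going by the values given here, the only measured step that bears on this change is the one on the same amine nitrogen, a number 5 percentage points higher from compound 1 to compound 2 (within the scatter), where a group of 7 heavy atoms gave way to a group of 3 heavy atoms and the number hardly moved. Among the compounds with values here, no measured compound carries a (4-nitrophenyl)sulfonyl group, and the entering group of 12 heavy atoms with its aromatic ring is unlike either group measured so far, so the expectation rests on a single step and is wide.

On that basis no step beyond the scatter is expected from compound 2 to compound 3, that is no change at the digits printed from compound 2 to compound 3 (within the scatter). Compound 3 is therefore estimated at 40%, with a range from 20% to 62%.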

Compound 3, a percentage reported as activity, at one concentration (the size of the read-out at that concentration, not a potency): 85%
Beside the measured number, compound 3's estimate is 45 percentage points below it; the measured number lies above the stated range.
By their numbers in this assay, from the lowest: compounds 1 and 2 (each within the scatter of the next); then compound 3.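

In this assay, the amine nitrogen on the double-bonded ring carbon proves far from indifferent to what it carries: (4-nitrophenyl)sulfonyl in place of carbamoyl gives a number 45 percentage points higher from compound 2 to compound 3 (beyond the scatter), and the same group in place of the open chain of 7 heavy atoms gives a number 50 percentage points higher from compound 1 to compound 3 (beyond the scatter). The two earlier compounds, whose step lies within the scatter, could have suggested a position where the substituent matters little, but the read-out here can clearly move beyond the scatter, and the sulfonyl group with its aromatic ring stands apart from both groups without a ring. Nothing measured here accounts for this difference.

The change brings in a sulfonyl link, a six-membered aromatic ring and a nitro group at once, so the compounds shown do not tell which of these parts goes with the higher number. A plain benzenesulfonyl group, a methanesulfonyl group or a benzoyl group on the same nitrogen would separate those parts, and the single test concentration leaves the potency of all three compounds open.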